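From compound 3 to a carboxy analogue

The source may hold more compounds than are shown below. What is called first, only, known or untested is meant among the compounds shown, and "the series" means these compounds.

Measured in a functional assay on DU-145 cells (Homo sapiens) for inhibition, read by trypan blue exclusion, with a stated time of 96 h; a higher number here means a weaker inhibitor of growth, a lower number a stronger inhibitor of growth:
compound 1 `O=C(/C(=C\c1ccc(O)c([N+](=O)[O-])c1)SCc1ccc(Br)cc1)c1ccc(Br)cc1` gives 10000 nM
compound 2 `O=C(/C(=C\c1cc(I)c(O)c(I)c1)SCc1ccc(Br)cc1)c1ccc(Br)cc1` gives 1000 nM
compound 3 `O=C(/C(=C\c1ccc([N+](=O)[O-])c(O)c1)SCc1ccc(Br)cc1)c1ccc(Br)cc1` gives 10000 nM

Level with compound 1, compound 3 stands at 10000 nM, and the two share the highest number of the three. Compound 2 lies furthest away, with a 10-fold higher number from compound 2 to compound 3 (1.00 log units; beyond the scatter). Compound 4 `O=C(/C(=C\c1ccc(O)c(C(=O)O)c1)SCc1ccc(Br)cc1)c1ccc(Br)cc1` differs from compound 3 in one place: 3-carboxy-4-hydroxyphenyl in place of 3-hydroxy-4-nitrophenyl on a double-bonded chain carbon bound to a double-bonded chain carbon. For the measured compounds named here, no measured compound carries the 3-carboxy-4-hydroxyphenyl group, so the expectation rests on indirect evidence. Exchanging one nitro-bearing group for the other gave no change at the digits printed from compound 1 to compound 3 (within the scatter). The only shift beyond the scatter, a 10-fold lower number from compound 1 to compound 2 (1.00 log units; beyond the scatter), brought in 4-hydroxy-3,5-diiodophenyl, a group that compound 4 lacks. No step beyond the scatter is therefore anticipated in this assay, in either direction. The expected step is no change at the digits printed from compound 3 to compound 4 (within the scatter), although this is uncertain. For compound 4 the estimated value is 10000 nM, with an expected range from 3000 nM to 30000 nM.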

Compound 4, concentration for 50% growth inhibition: 10000 nM
Compound 4: the middle estimate sits on the measured number at the digits printed, and the stated range covers the measured number.
By their numbers in this assay, from the lowest: compound 2; then compounds 1, 3 and 4 (each within the scatter of the next).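

In this assay, replacing either nitro-bearing group with the 3-carboxy-4-hydroxyphenyl group left the number unmoved, with no change at the digits printed from compound 3 to compound 4 (within the scatter) and, for carboxy in place of nitro on an aromatic carbon, no change at the digits printed from compound 1 to compound 4 (within the scatter). At this place, on a double-bonded chain carbon bound to a double-bonded chain carbon, the result therefore extends the earlier picture to a group that carries no nitrogen and two hydrogen-bond donors rather than one. The 4-hydroxy-3,5-diiodophenyl group of compound 2 remains the only one set apart, with a 10-fold higher number from compound 2 to compound 4 (1.00 log units; beyond the scatter).

The compounds shown offer no explanation for these steps. They also leave open whether an amine or a methyl ester in place of the carboxy group would stay within the scatter of compound 4, and whether a single iodo group would be enough to reach the number of compound 2.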